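The source may report more compounds than this note shows. Statements on the series, on what has been measured and on what is new or still open speak of the compounds shown alone.

Compound 1 `N#CC1(NC(=O)[C@@H]2C[C@@H](S(=O)(=O)c3ccccc3)C[C@H]2C(=O)N2CCC2)CC1`: 44 nM
Compound 2 `N#CC1(NC(=O)[C@@H]2C[C@@H](S(=O)(=O)c3ccccc3)CN2C(=O)c2ccccc2)CC1`: 217 nM
Compound 3 `N#CC1(NC(=O)[C@@H]2C[C@@H](S(=O)(=O)c3ccccc3Cl)CN2C(=O)c2ccccc2)CC1`: 15 nM

All three compounds were tested in a functional assay on A20 cells (Mus musculus) for inhibition, with stated times of 1 h, 16 h and 24 h; on this read-out higher numbers stand for weaker inhibition and lower numbers for stronger inhibition. Compound 3 gives the lowest of the three numbers, 15 nM. Compound 4 `CC(=O)N1C[C@H](S(=O)(=O)c2ccccc2Cl)C[C@H]1C(=O)NC1(C#N)CC1` differs from it in one place, benzoyl to acetyl, which is methyl in place of phenyl on a carbonyl carbon.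

Within the data shown here, the only measured single-place step is a 14-fold lower number from compound 2 to compound 3 (1.16 log units; beyond the scatter). It is large, but it concerns chloro in place of hydrogen on an aromatic carbon, so it does not test the present change. Among the measured compounds shown here, no measured pair does. Compound 1 has no benzoyl and differs from the others in more than one place, so its 44 nM offers only a loose hint that a compound without that group can still give a low number. A moderate rise in this assay is therefore expected, with wide uncertainty. The estimate means a 2.3-fold higher number from compound 3 to compound 4 (0.37 log units; beyond the scatter), an expected step towards weaker inhibition. For compound 4 the estimated value is 35 nM, with an expected range from 10 nM to 120 nM.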

Compound 4, half-maximal inhibitory concentration: 19 nM
Beside the measured number, compound 4's estimate is 1.8-fold (0.27 log units) above it, and the stated range covers the measured number.
By their numbers in this assay, from the lowest: compounds 3 and 4 (each within the scatter of the next); then compound 1; then compound 2.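

In this assay, the change from benzoyl to acetyl on the carbonyl carbon gives a 1.3-fold higher number from compound 3 to compound 4 (0.10 log units; within the scatter), so this position tolerates the exchange of phenyl for methyl. Among these compounds, with the chloro group present, the low number therefore does not depend on the phenyl of the benzoyl group, a point that the earlier compounds could not settle. Nothing measured here gives a reason for this result.

As far as these compounds go, the acetyl group appears only together with the chloro group, so it remains open whether it would give a similar number with hydrogen on that aromatic carbon. The compounds shown also leave open how a longer chain such as propyl, or an amine such as dimethylamino, would read on the same carbonyl carbon.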